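Ring Size on the Amide Nitrogen of a Weak Antiproliferative

The source may report more compounds than this note shows. Statements on the series, on what has been measured and on what is new or still open speak of the compounds shown alone.

Compound 1 `O=C1COc2ccc(-c3cccc(NS(=O)(=O)c4ccc(F)cc4)c3)cc2N1C1CC1` carries a cyclopropyl on the amide-type nitrogen of its fused core. In a functional assay on HCT-116 cells (Homo sapiens) for antiproliferative activity, read by MTT assay, with a stated time of 72 h (a lower number here means a stronger inhibitor, a higher number a weaker inhibitor), compound 1 gives only a limit of the assay, > 40000 nM. Two companions with a different aromatic linker bear either a 4-fluorophenyl or a cyclopropyl on that same nitrogen: compound 2 `O=C1COc2ccc(-c3cnc(Cl)c(NS(=O)(=O)c4ccc(F)cc4)c3)cc2N1c1ccc(F)cc1` gives 34200 nM, and compound 3 `O=C1COc2ccc(-c3cnc(Cl)c(NS(=O)(=O)c4ccc(F)cc4)c3)cc2N1C1CC1` gives 12400 nM. For the measured compounds named here, the single measured change at this nitrogen is a 2.8-fold lower number from compound 2 to compound 3 (0.44 log units; beyond the scatter), a modest step.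

Compound 4 `O=C1COc2ccc(-c3cccc(NS(=O)(=O)c4ccc(F)cc4)c3)cc2N1C1CCCCC1` differs from compound 1 by cyclohexyl in place of cyclopropyl on an amide-type nitrogen in a ring. That measured step compares cyclopropyl with 4-fluorophenyl rather than with cyclohexyl, so it bears on the position but not on the new group itself, and compound 1 rests at the limit of > 40000 nM in this assay, at which 1 of the 3 values shown sits, leaving no number to move from. No shift beyond the scatter is therefore expected, and a second limit is the likelier outcome. Compound 4 is estimated at 40000 nM, within a range from 15000 nM to 100000 nM, so that the expected step is a number no higher from compound 1 to compound 4 (the limit leaves the size open).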

Compound 4, half-maximal inhibitory concentration: 18300 nM
Beside the measured number, compound 4's estimate is 2.2-fold (0.34 log units) above it, and the stated range covers the measured number.
By their numbers in this assay, from the lowest: compounds 3, 4 and 2 (each within the scatter of the next, the first and the last beyond it). At a limit, above all of these: compound 1.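

In this assay, for the compounds shown here, cyclohexyl in place of cyclopropyl gives an at least 2.1-fold lower number from compound 1 to compound 4 (0.33 log units; beyond the scatter), the first measured change at this nitrogen with the linker of compound 1. Cyclopropyl gave the lower number against 4-fluorophenyl in the earlier pair, but here it gives way to a six-membered carbon ring, so no simple order of these groups holds across the two linkers, and compound 4 goes against any reading that favours cyclopropyl. The true size of the new step remains unfixed, since one end of it is not a number: the limit of > 40000 nM in this assay, at which 1 of the 4 values shown sits.

As far as these compounds go, whether cyclohexyl would also lower the number with the linker of compound 3 remains open. So does the outcome with a piperidine ring or a longer alkyl chain on this nitrogen.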